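The source may hold more compounds than are shown below. What is called first, only, known or untested is meant among the compounds shown, and "the series" means these compounds.

Measured compounds:
compound 1 `CN(C)C(=O)c1ccncc1Nc1cc(-c2ccc3ccn(C)c3c2)c2nccnc2c1`; in an assay on lysate for inhibition of 6-phosphofructo-2-kinase/fructose-2,6-bisphosphatase 3 (Homo sapiens), with stated times of 0.5 min and 45 min (a higher number here means a weaker inhibitor, a lower number a stronger inhibitor), it reaches only a limit, > 100000 nM
compound 2 `CN1CCC(CNC(=O)c2ccncc2Nc2cc(-c3ccc4ccn(C)c4c3)c3nccnc3c2)C1`; in this assay compound 2 gives 24000 nM

Compound 2 holds the only number shown in this assay; the other value is a limit, (the limit of > 100000 nM in this assay, at which 1 of the 2 values shown sits). Among the measured compounds shown here, the single measured step is an at least 4.1-fold lower number from compound 1 to compound 2 (0.61 log units; beyond the scatter).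

Compound 3 `CN1CCC(N(C)C(=O)c2ccncc2Nc2cc(-c3ccc4ccn(C)c4c3)c3nccnc3c2)C1` differs from compound 2 by methyl(1-methylpyrrolidin-3-yl)amino in place of ((1-methylpyrrolidin-3-yl)methyl)amino on a carbonyl carbon. The measured step changed the amide substituent itself, so it bears on this change only loosely; here the same atoms are rearranged, the amide hydrogen is lost. Nothing measured argues for a change beyond the scatter. For compound 3 the estimate in this assay is 25000 nM, between 8000 nM and 80000 nM. The expected step is a 1.0-fold higher number from compound 2 to compound 3 (0.02 log units; within the scatter).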

Compound 3, half-maximal inhibitory concentration: 39700 nM
Compound 3: the middle estimate sits 1.6-fold (0.20 log units) below what was measured; the range from low to high includes it.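

In this assay, the amide hydrogen can be lost and the same atoms rearranged with no change beyond the scatter: a 1.7-fold higher number from compound 2 to compound 3 (0.22 log units; within the scatter). With 1-methylpyrrolidin-3-yl in place of methyl on an amide-type nitrogen, the number still falls relative to dimethylamino, an at least 2.5-fold lower number from compound 1 to compound 3 (0.40 log units; beyond the scatter), so the pyrrolidine-bearing amide does not depend on the amide hydrogen. The true size of this step stays unknown, since the value for compound 1 is a limit: the limit of > 100000 nM in this assay, at which 1 of the 3 values shown sits.

Open, going by these compounds, is whether a piperidine, a primary amine or a longer chain on the amide nitrogen would move the number beyond the scatter.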